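Ester variation on a tert-butyl phenol core: methoxy entry

The source may hold more compounds than are shown below. What is called first, only, known or untested is meant among the compounds shown, and "the series" means these compounds.

Compound 1 `CC(C)(C)c1cc(OC(=O)c2ccco2)ccc1O` gives > 100000 nM in an assay on isolated protein for antagonist activity at Bile acid receptor (Homo sapiens), read by HTRF, with a stated time of 30 min; a higher number here means a weaker inhibitor, a lower number a stronger inhibitor; this is a limit of the assay.
Compound 2 `Cc1ccc(C(=O)Oc2ccc(O)c(C(C)(C)C)c2)cc1` gives > 100000 nM in this assay; this is a limit.
Compound 3 `CC(C)(C)c1cc(OC(=O)c2ccccc2)ccc1O` gives > 100000 nM in this assay; this is a limit.

Compound 3 stands at a limit only, and no number separates it from its two neighbours. The step that the two limits leave unreadable from compound 1 to compound 3 and the step that the two limits leave unreadable from compound 2 to compound 3 both start and end at limits, as does the step that the two limits leave unreadable from compound 1 to compound 2, so the size of none of them can be read. All three measured values sit at the same point, (the limit of > 100000 nM in this assay, at which 3 of the 3 values shown sit).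

Compound 4 `COc1ccccc1C(=O)Oc1ccc(O)c(C(C)(C)C)c1` differs from compound 3 by methoxy in place of hydrogen on an aromatic carbon. Among the compounds with values here, none of the measured steps touches this change, and those that exist are unreadable, so they give no direction for this assay. Given that every compound of the series so far returns only a limit, the expected outcome for compound 4 is again no measurable inhibition, with the step that the limit leaves unreadable from compound 3 to compound 4 estimated as essentially none. Compound 4 is therefore estimated at 150000 nM, with a range from 30000 nM to 1000000 nM.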

Compound 4, half-maximal inhibitory concentration: > 100000 nM
Compound 4 gave a limit, no number; the forecaster's own chance of this, stated with the estimate: 85%; the middle value lies beyond the limit too.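

Compound 4, like compound 3, stands only at a limit, so the step between them joins two limits and its size cannot be read. The compounds shown leave open whether any ester on the shared core gives measurable inhibition in this assay, as every value sits at one point: the limit of > 100000 nM in this assay, at which 4 of the 4 values shown sit.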